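From a Carbamoyl-Ethenyl Arm to an Acetylphenyl Group

The source may report more compounds than this note shows. Statements on the series, on what has been measured and on what is new or still open speak of the compounds shown alone.

Of the compounds shown here, two on a shared core have been measured in an assay on isolated protein with Bile acid receptor (Homo sapiens) as the target; on this read-out lower numbers stand for an effect already at smaller amounts and higher numbers for an effect only at larger amounts of compound. Compound 1 `COC(=O)/C=C/c1cccc(N(Cc2ccc(/C=C/C(=O)OCc3ccccc3)cc2)C(=O)C2CCCCC2)c1` carries benzyloxy on a carbonyl carbon; in this assay compound 1 gives only a limit, > 1000 nM. Compound 2 `COC(=O)/C=C/c1cccc(N(Cc2ccc(/C=C/C(=O)NC(C)(C)C)cc2)C(=O)C2CCCCC2)c1` has (tert-butyl)amino in place of benzyloxy on that carbonyl carbon; in this assay compound 2 likewise gives only a limit, > 1000 nM. The step that the two limits leave unreadable from compound 1 to compound 2 cannot be read, since both values sit at the limit of > 1000 nM in this assay, at which 2 of the 2 values shown sit. Compound 2 thus stands at the limit of the assay, and where it lies beyond that limit is not known.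

Compound 3 `COC(=O)/C=C/c1cccc(N(Cc2ccc(-c3cccc(C(C)=O)c3)cc2)C(=O)C2CCCCC2)c1` carries the change 3-acetylphenyl in place of 2-((tert-butyl)carbamoyl)ethenyl on an aromatic carbon, para to a large group. Among the compounds with values here, no measured step bears on this change, and the one measured step is unreadable. An expectation for compound 3 can rest only on the two limits, so no step beyond the scatter is expected in either direction, and the estimated step that the limit leaves unreadable from compound 2 to compound 3 is set near zero. Compound 3 is accordingly estimated at 2000 nM, with a range from 500 nM to 10000 nM.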

Compound 3, half-maximal effective concentration: 227 nM
Compound 3: middle estimate off by 8.8-fold (0.95 log units), on the high side; the whole stated range lies above it.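

At this aromatic carbon, para to a large group, 3-acetylphenyl in place of 2-((tert-butyl)carbamoyl)ethenyl gives a step that can be read in this assay: an at least 4.4-fold lower number from compound 2 to compound 3 (0.64 log units; beyond the scatter). With 3-acetylphenyl in place of 2-(benzyloxycarbonyl)ethenyl the picture is the same, an at least 4.4-fold lower number from compound 1 to compound 3 (0.64 log units; beyond the scatter), so this position can shift the read-out, which the unreadable step between the two earlier compounds could not show. Both steps give only a minimum size, because compound 1 and compound 2 each sit at a limit and their true values are not known: the limit of > 1000 nM in this assay, at which 2 of the 3 values shown sit.

The change replaces an open arm holding a hydrogen-bond donor with an aromatic ring of carbon only that has no such donor, so the compounds shown do not separate the part played by the ring, by the acetyl group or by the loss of the amide hydrogen. Going by these compounds, it also stays open whether a plain phenyl group, or a phenyl ring carrying a nitrile or a carboxylic acid in place of the acetyl group, would keep the lower number seen for compound 3.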